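Adding a Second Chloro to Compound 2

This account rests on a few compounds, and the source may have more. Where it says the series, first, only, none or still open, it means among the compounds named here.

- compound 1 `COc1cc(/C=C2\CN(C)C/C(=C\c3ccccc3F)C2=O)cc(OC)c1`: 1240 nM
- compound 2 `COc1cc(/C=C2\CN(C)C/C(=C\c3ccc(Cl)cc3)C2=O)cc(OC)c1`: 5950 nM

In a functional assay on HepG2 cells (Homo sapiens) for cytotoxicity, read by MTT assay, with a stated time of 24 h (on this read-out higher numbers stand for weaker inhibition and lower numbers for stronger inhibition), compound 2 has the higher of the two numbers at 5950 nM, which makes it the weaker inhibitor of this pair. The next structure, compound 3 `COc1cc(/C=C2\CN(C)C/C(=C\c3ccc(Cl)cc3Cl)C2=O)cc(OC)c1`, differs from compound 2 in one place: chloro in place of hydrogen on an aromatic carbon. This puts chloro in place of hydrogen on an aromatic carbon, ortho to a large group and meta to a chloro group, so 4-chlorophenyl becomes 2,4-dichlorophenyl.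

Within the data shown here, no measured step makes exactly this change. Among the measured compounds shown here, the only guide is a 4.8-fold higher number from compound 1 to compound 2 (0.68 log units; beyond the scatter), which replaces 2-fluorophenyl with 4-chlorophenyl and lies beyond the scatter. The new 2,4-dichlorophenyl echoes both groups, although it carries chloro rather than fluoro. A modest move toward a lower number in this assay therefore seems likely, probably smaller than that measured step, but this rests on a single comparison. The expected change is a 2.1-fold lower number from compound 2 to compound 3 (0.33 log units; beyond the scatter). For compound 3 the estimated value is 2800 nM, with an expected range of 1000 nM to 7000 nM.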

Compound 3, half-maximal inhibitory concentration: 6250 nM
Compound 3: the middle estimate sits 2.2-fold (0.35 log units) below what was measured; the measured number falls inside the stated range.
By their numbers in this assay, from the lowest: compound 1; then compounds 2 and 3 (each within the scatter of the next).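

In this assay, chloro in place of hydrogen on an aromatic carbon, ortho to a large group and meta to a chloro group, gives a 1.1-fold higher number from compound 2 to compound 3 (0.02 log units; within the scatter) and so leaves 4-chlorophenyl and 2,4-dichlorophenyl indistinguishable on this read-out. Replacing 2-fluorophenyl with 2,4-dichlorophenyl gives a 5.0-fold higher number from compound 1 to compound 3 (0.70 log units; beyond the scatter) and shows that, with the chloro of compound 2 kept, a halogen ortho to a large group does not by itself give a number as low as that of compound 1. No measurement at hand offers a reason for these numbers.

Compound 1 and compound 2 differ in both the halogen and where it sits, so the compounds shown cannot separate what fluoro in place of chloro contributes from what the position contributes. As far as these compounds go, how the same aromatic carbon would read with a quite different group, such as an amine or a carboxylic acid, also stays open, as does any change to the other aromatic ring or to the rest of the shared core.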